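Removing the ring methyl from compound 1: an expectation

The source may report more compounds than this note shows. Statements on the series, on what has been measured and on what is new or still open speak of the compounds shown alone.

Measured so far:
Compound 1 `COc1cc2c(Nc3nc4ccc(C(=O)Nc5c(C)cccc5Cl)cc4s3)ncnc2cc1OCCCN1CCCCC1C`: 6700 nM
Compound 2 `COc1cc2c(Nc3nc4ccc(C(=O)Nc5c(C)cc(C)cc5C)cc4s3)ncnc2cc1OCCCN1CCCCC1C`: 5800 nM

Both compounds share one core and were tested in a functional assay on A549 cells (Homo sapiens) for cytotoxicity, read by WST assay, with a stated time of 72 h; a lower number here means a stronger inhibitor, a higher number a weaker inhibitor. On the two numbers available, compound 1 stands with the higher value, and its nearest neighbour is compound 2. Going by the values given here, the only measured step, a 1.2-fold lower number from compound 1 to compound 2 (0.06 log units; within the scatter), falls within the scatter, so the two compounds cannot be ordered.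

Compound 3 `COc1cc2c(Nc3nc4ccc(C(=O)Nc5c(C)cccc5Cl)cc4s3)ncnc2cc1OCCCN1CCCCC1` is not yet measured. It differs from compound 1 in that (hydrogen in place of methyl on a saturated ring carbon). Among the compounds with values here, the one measured step concerns the aryl group on the amide-type nitrogen, a different part of the molecule, and therefore does not bear on this change. Within the data shown here, no measured step speaks to removal of a methyl from the saturated ring, and no pattern can be drawn from a single pair.

With nothing to point either way, compound 3 is expected to give 6700 nM in this assay, with a range from 2500 nM to 18000 nM. The expected step, no change at the digits printed from compound 1 to compound 3 (within the scatter), is estimated to be none beyond the scatter.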

Compound 3, half-maximal inhibitory concentration: 12800 nM
Beside the measured number, compound 3's estimate is 1.9-fold (0.28 log units) below it, within the range that was stated.
By their numbers in this assay, from the lowest: compounds 2, 1 and 3 (each within the scatter of the next, the first and the last beyond it).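

Taking the methyl off the saturated ring carbon gives the first measured step at this position: in this assay, a 1.9-fold higher number from compound 1 to compound 3 (0.28 log units; within the scatter). The step stays within the scatter, so 2-methylpiperidin-1-yl and piperidin-1-yl cannot be told apart on the core of compound 1, and this assay gives no sign that the methyl matters at this place. Going by these compounds alone, the earlier pair spoke only to the aryl group on the amide-type nitrogen, so this is the first reading on the saturated ring, and no evidence on the origin of this result is available.

The compounds shown leave open whether an ethyl or a hydroxyl on the same ring carbon, or a dimethylamino group in place of the whole piperidin-1-yl, would give a step beyond the scatter. They also leave open whether piperidin-1-yl and 2-methylpiperidin-1-yl would still read alike with the 2,4,6-trimethylphenyl group of compound 2 on the amide-type nitrogen.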